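Removing the chloro from compound 1: what to expect

The source may report more compounds than this note shows. Statements on the series, on what has been measured and on what is new or still open speak of the compounds shown alone.

Measured compounds:
compound 1 `COc1cc(/C=C/C(=O)c2cccc(-n3cc(-c4ccc(Cl)cc4)[nH]c3=O)c2)cc(OC)c1OC` — 13800 nM
compound 2 `O=C(/C=C/c1cccc(O)c1)c1cccc(-n2cc(-c3ccc(Cl)cc3)[nH]c2=O)c1` — 3350 nM

Among the compounds with values here, in a functional assay on MDA-MB-231 cells (Homo sapiens) for inhibition (a higher number here means a weaker inhibitor of growth, a lower number a stronger inhibitor of growth), compound 1 gives 13800 nM, the highest of the two numbers known, while compound 2 gives 3350 nM, a lower number that lies beyond the usual scatter. Compound 3 `COc1cc(/C=C/C(=O)c2cccc(-n3cc(-c4ccccc4)[nH]c3=O)c2)cc(OC)c1OC` differs from compound 1 by a single change: hydrogen in place of chloro on an aromatic carbon. Within the data shown here, no measured pair shows this change, so its effect is unknown. Only a small step is expected, none beyond the scatter, and the estimated step of a 1.1-fold higher number from compound 1 to compound 3 (0.04 log units; within the scatter) reflects this. Compound 3 is therefore expected to give about 15000 nM, within a range from 6000 nM to 40000 nM.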

Compound 3, concentration for 50% growth inhibition: 2170 nM
Estimate against measurement, compound 3: 6.9-fold (0.84 log units) above; measured number outside the range, below it.
By their numbers in this assay, from the lowest: compounds 3 and 2 (each within the scatter of the next); then compound 1.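

In this assay, the change from 4-chlorophenyl to phenyl gives a 6.4-fold lower number from compound 1 to compound 3 (0.80 log units; beyond the scatter), so the chloro at this place matters: within this pair, the compound without it is the stronger inhibitor of growth. Within the data shown here, this is the first single-change step at this position. Nothing available here accounts for the step.

Going by these compounds, whether a fluoro, a methyl or an amine at this place would behave like the chloro or like the hydrogen remains open. So does whether removing the chloro from compound 2 would give a similar step.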